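This account rests on a few compounds, and the source may have more. Where it says the series, first, only, none or still open, it means among the compounds named here.

Working notes on the series. Compound 1 `COc1cccc(NC(=O)/C=C/c2coc3cc(OC)ccc3c2=O)c1` carries a 3-methoxyphenyl on the amide-type nitrogen; in a functional assay (QGY7701 cells, Homo sapiens) for inhibition, read by MTT assay, with a stated time of 48 h (a higher number here means a weaker inhibitor, a lower number a stronger inhibitor), compound 1 gives 39100 nM. Compound 2 `COc1ccc2c(=O)c(/C=C/C(=O)Nc3ccc(Cl)cc3)coc2c1` has 4-chlorophenyl in that place. In this assay compound 2 reaches only > 100000 nM, which is a limit of the assay and not a number. For the measured compounds named here, the single measured step is an at least 2.5-fold higher number from compound 1 to compound 2 (0.40 log units; beyond the scatter), and its size is set by the limit of > 100000 nM in this assay, at which 1 of the 2 values shown sits. Compound 3 `COc1ccc2c(=O)c(/C=C/C(=O)Nc3ccc(C)cc3)coc2c1` is the next pair member: methyl in place of chloro on an aromatic carbon. Going by the values given here, no measured step bears directly on a chloro-to-methyl swap here; the only step available is the larger 1>2 exchange, so compound 3 is expected to stay near compound 2 with a step of about an at least 1.1-fold lower number from compound 2 to compound 3 (0.04 log units; that floor lies within the scatter), not beyond the scatter in either direction. The estimate for compound 3 in this assay is 90000 nM, between 30000 nM and 300000 nM, with a fair chance that only a limit is reported.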

Compound 3, half-maximal inhibitory concentration: 39300 nM
Compound 3: the middle estimate sits 2.3-fold (0.36 log units) above what was measured, within the range that was stated.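

In this assay, the exchange of chloro for methyl on this aromatic carbon is enough on its own to move the result, with an at least 2.5-fold lower number from compound 2 to compound 3 (0.40 log units; beyond the scatter). The step from compound 1 was read earlier with two things differing on the aryl group; here, 4-methylphenyl and 3-methoxyphenyl on the amide-type nitrogen cannot be told apart, with a 1.0-fold higher number from compound 1 to compound 3 (0.00 log units; within the scatter), so the weak end of the series rests on the 4-chlorophenyl case alone. The chloro-to-methyl step has a known floor but no known size, and it rests on a limit of the assay: the limit of > 100000 nM in this assay, at which 1 of the 3 values shown sits.

Going by these compounds, whether any other group at this carbon behaves like methyl or like chloro stays open; a fluoro, an amine or a carboxylic acid would test that. Also open, on these data alone, is how 4-methoxyphenyl compares with 3-methoxyphenyl on the same nitrogen.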